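Ester to Amide and Back: a Small Series Continues

A few compounds are considered here, and "the series" means these few. Any claim that something is new, unique, unknown or untested is made for them only; others in the source may bear on it.

Of the compounds shown here, two share a core and have been measured in an assay on membranes from CHO cells for displacement of a labelled ligand from adenosine receptor A1 (Homo sapiens), read by scintillation counting, with a stated time of 60 min, tested at 1 uM; a higher number here means more inhibition at the concentration tested (going by the name of the read-out), a lower number less inhibition. Compound 1 `COC(=O)C1=C(C)NC(=O)NC1c1ccoc1` gives 8%. Compound 2 `CCNC(=O)C1=C(C)NC(=O)NC1c1ccoc1`, which differs only where an ethylamino replaces a methoxy on the carbonyl carbon, gives 1%. Compound 2 holds the lowest of the two numbers, though its nearest neighbour, compound 1, sits within the usual scatter of it, with a number 7 percentage points lower from compound 1 to compound 2 (within the scatter).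

Within the data shown here, compound 3 `CC1=C(C(=O)OC2CCCC2)C(c2ccoc2)NC(=O)N1` is not yet measured. cyclopentyloxy in place of ethylamino on a carbonyl carbon The only measured step, from compound 1 to compound 2, swapped an ester for an amide and moved within the scatter; the new step goes back to an ester but with a larger group, and no measured pair covers that. The expected step is therefore a number 7 percentage points higher from compound 2 to compound 3 (within the scatter), with no clear direction beyond the scatter. Compound 3 is estimated at 8%, in a range from -10% to 30%.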

Compound 3, a percentage reported as inhibition, at one concentration (the size of the read-out at that concentration, not a potency): 6%
Estimate against measurement, compound 3: 2 percentage points above; the measured number falls inside the stated range.
By their numbers in this assay, from the lowest: compounds 2, 3 and 1 (each within the scatter of the next).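

In this assay, putting cyclopentyloxy in place of ethylamino gives a number 5 percentage points higher from compound 2 to compound 3 (within the scatter) and so does not separate the two groups, even though the swap brings in a ring of carbon only and removes the amide hydrogen. Enlarging the group on the ester oxygen from methyl to cyclopentyl gives a number 2 percentage points lower from compound 1 to compound 3 (within the scatter) and does not separate those two compounds either, so among these three compounds the size of the group on this carbonyl carbon has no readable effect on the result. No other information on these compounds bears on this result.

On these data alone, what stays open is whether any group at this carbonyl carbon can lift the inhibition clear of the scatter. A carboxylic acid, a benzyl ester or a longer chain on the amide nitrogen would each test that further.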